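The source may hold more compounds than are shown below. What is called first, only, known or untested is meant among the compounds shown, and "the series" means these compounds.

Measured so far:
compound 1, `Cc1c(OCCCCOc2ccc(Cl)c(C(=O)O)c2)ccc(C(=O)CC(C)(C)C)c1O`: 130 nM
compound 2, `Cc1c(OC[C@H](C)Oc2ccc(F)c(C(=O)O)c2)ccc(C(=O)CC(C)(C)C)c1O`: 1100 nM

In an assay for positive allosteric modulation of metabotropic glutamate receptor 3 (Rattus norvegicus) (on this read-out lower numbers stand for an effect already at smaller amounts and higher numbers for an effect only at larger amounts of compound), compound 2 gives 1100 nM, the higher of the two numbers; compound 1 gives 130 nM, and that gap lies beyond the scatter. Compound 3, `Cc1c(OC[C@@H](C)Oc2ccc(F)c(C(=O)O)c2)ccc(C(=O)CC(C)(C)C)c1O`, keeps every atom and bond of compound 2: the two compounds have the same atoms and bonds and differ only in configuration as drawn: 1 of 1 stereo elements differ; a stereocentre at a saturated chain carbon is drawn S in compound 2 and R in compound 3. For the measured compounds named here, no measured pair differing only in configuration is at hand, so the direction of this step is open and either enantiomer could carry the activity. In this assay a step of a 1.6-fold lower number from compound 2 to compound 3 (0.20 log units; within the scatter) is expected, with wide uncertainty. Compound 3 is expected to give 700 nM, in the range 150 nM to 3500 nM.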

Compound 3, half-maximal effective concentration: 1210 nM
For compound 3 the middle estimate is 1.7-fold (0.24 log units) below the measured one, and the stated range covers the measured number.
By their numbers in this assay, from the lowest: compound 1; then compounds 2 and 3 (each within the scatter of the next).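

In this assay the stereocentre at the saturated chain carbon gives a 1.1-fold higher number from compound 2 to compound 3 (0.04 log units; within the scatter), so on this read-out the S and R forms cannot be told apart. Neither enantiomer stands out as carrying the activity in this pair, and the reading concerns this one centre alone: the fact that compounds 2 and 3 differ only in the configuration as drawn

Compound 1 differs from both in more than one place, so it adds nothing on this centre. As far as these compounds go, whether configuration at this carbon would matter with an ethyl branch or a hydroxyl group there remains open.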